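Swapping Methoxy for Hydroxy on a Small Series

This account rests on a few compounds, and the source may have more. Where it says the series, first, only, none or still open, it means among the compounds named here.

In a functional assay, with a stated time of 10 min (a higher number here means a weaker inhibitor, a lower number a stronger inhibitor), compound 1 `O=c1cc(/C=C/c2ccccc2O)[nH]cc1O` gives 2210 nM, compound 2 `Cn1cc(O)c(=O)cc1/C=C/c1ccccc1` gives 2110 nM and compound 3 `COc1ccccc1/C=C/c1cc(=O)c(O)cn1C` gives 4170 nM. The gaps from compound 3 to the other two lie within the scatter of repeated measurements, so the three cannot be ranked.

Compound 4 `Cn1cc(O)c(=O)cc1/C=C/c1ccccc1O` differs from compound 3 in one place: hydrogen in place of methyl on an oxygen on an aromatic ring. This is hydrogen in place of methyl on an oxygen on an aromatic ring, which turns methoxy into hydroxy.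

For the measured compounds named here, no measured step makes this exact swap. The closest is a 2.0-fold higher number from compound 2 to compound 3 (0.30 log units; within the scatter), which places methoxy on an aromatic carbon in place of hydrogen and stays within the scatter. Compound 1 also carries a hydroxy and gives 2210 nM, though it lacks a methyl that compound 4 keeps. Nothing here therefore points to a change beyond the scatter.

The expected step is small, at a 1.6-fold lower number from compound 3 to compound 4 (0.21 log units; within the scatter). For compound 4 the estimate in this assay is 2600 nM, with an expected range of 1200 nM to 5500 nM.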

Compound 4, half-maximal inhibitory concentration: 1830 nM
Beside the measured number, compound 4's estimate is 1.4-fold (0.15 log units) above it; the measured number falls inside the stated range.
By their numbers in this assay, from the lowest: compounds 4, 2, 1 and 3 (each within the scatter of the next, the first and the last beyond it).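

In this assay, for the compounds shown here, hydrogen in place of methyl on the oxygen gives a 2.3-fold lower number from compound 3 to compound 4 (0.36 log units; beyond the scatter) and this is the first step to clear the scatter, though only modestly. The hydroxy itself does not stand apart from a plain hydrogen on that aromatic carbon, as a 1.2-fold lower number from compound 2 to compound 4 (0.06 log units; within the scatter) shows, and the methyl on the aromatic nitrogen has no readable effect either, with a 1.2-fold lower number from compound 1 to compound 4 (0.08 log units; within the scatter) as its step, so the one clear separation here is methoxy against hydroxy. Nothing shown here bears on why this step arises.

On these data alone, whether an ethoxy, an amine or a carboxylic acid at this place would sit nearer to the methoxy or to the hydroxy stays open. So does whether the methoxy-to-hydroxy step would hold on the core of compound 1, which has hydrogen on the nitrogen.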